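The source may report more compounds than this note shows. Statements on the series, on what has been measured and on what is new or still open speak of the compounds shown alone.

Measured so far in a functional assay on cells (Mus musculus) for antiproliferative activity, read by sulforhodamine B assay, with a stated time of 5 days; a higher number here means a weaker inhibitor, a lower number a stronger inhibitor:
Compound 1, `COc1cc(NC(=O)Nc2cc(C(F)(F)F)cc(C(F)(F)F)c2)ccc1C`, gives 6600 nM.
Compound 2, `O=C(Nc1ccc(Cl)c(Cl)c1)Nc1ccc(Cl)c(Cl)c1`, gives only a limit of the assay, > 20000 nM.

Going by the values given here, compound 1 thus supplies the only actual number in this set. Among the compounds with values here, the other value shown is a limit, (the limit of > 20000 nM in this assay, at which 1 of the 2 values shown sits), so no measured step exists against which compound 1 can be ranked, and nothing can be said of its standing beyond its own number.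

Compound 3, `Cc1ccc(NC(=O)Nc2cc(C(F)(F)F)cc(C(F)(F)F)c2)cc1O`, differs from compound 1 by hydrogen in place of methyl on an oxygen on an aromatic ring. Within the data shown here, no measured pair in this set isolates such a change, so any expectation for compound 3 rests on the single number of compound 1 alone, 6600 nM being the one anchor available. A change of this size is expected to move the result little, in either direction. The expected step, a 1.1-fold lower number from compound 1 to compound 3 (0.04 log units; within the scatter), is estimated to stay within the usual scatter of this assay. For compound 3 the estimate is therefore 6000 nM, with a range from 2500 nM to 15000 nM.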

Compound 3, half-maximal inhibitory concentration: 15700 nM
Compound 3: the middle estimate sits 2.6-fold (0.42 log units) below what was measured; measured number above the stated range.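

In this assay, going by these compounds alone, the change from methoxy to hydroxy gives a 2.4-fold higher number from compound 1 to compound 3 (0.38 log units; beyond the scatter), the first measured step, and it lies beyond the scatter, though it is modest. It shows that this oxygen substituent on the aromatic ring is not a silent position: removing a single methyl, with the rest of the core of compound 1 unchanged, is enough to register in the read-out, and within this pair the methoxy form carries the lower number. The compounds shown hold no measurement that accounts for the size or direction of this step.

On these data alone, what remains open is whether the step reflects the loss of the methyl or the presence of the free hydroxy, and a single pair at a single position cannot separate the two. An ethoxy group or a longer chain on the same oxygen, or an amine in place of the hydroxy, would show whether the number in this assay keeps moving with the group at this place or whether this step stands alone.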